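A few compounds are considered here, and "the series" means these few. Any claim that something is new, unique, unknown or untested is made for them only; others in the source may bear on it.

Working notes on the series. Compound 1 `N#Cc1ccc2ccc(Oc3ccccc3OCCn3ccc(=O)[nH]c3=O)cc2c1` gives 15000 nM in a toxicity assay on MT2 cells (Homo sapiens) for cytotoxicity, read by MTT assay; on this read-out lower numbers stand for higher toxicity in this test and higher numbers for lower toxicity in this test. Compound 2 `N#Cc1ccc2c(Cl)cc(Oc3ccccc3OCCn3ccc(=O)[nH]c3=O)cc2c1` carries chloro in place of hydrogen on an aromatic carbon; in this assay compound 2 gives 12000 nM, a step of a 1.3-fold lower number from compound 1 to compound 2 (0.10 log units; within the scatter). Compound 3 `N#Cc1ccc2ccc(Oc3ccc(F)cc3OCCn3ccc(=O)[nH]c3=O)cc2c1` differs from compound 1 by fluoro in place of hydrogen on an aromatic carbon. For compound 3 this assay reports only a limit, > 100000 nM, at the limit of > 100000 nM in this assay, at which 1 of the 3 values shown sits. The step of an at least 6.6-fold higher number from compound 1 to compound 3 (0.82 log units; beyond the scatter) is therefore bounded from one side only. Compound 4 `N#Cc1ccc2c(Cl)cc(Oc3ccc(F)cc3OCCn3ccc(=O)[nH]c3=O)cc2c1` is not yet measured in this assay; it differs from compound 3 by chloro in place of hydrogen on an aromatic carbon, the same change as from compound 1 to compound 2. Going by the earlier step of a 1.3-fold lower number from compound 1 to compound 2 (0.10 log units; within the scatter), the step of a number no higher from compound 3 to compound 4 (the limit leaves the size open) is expected to be small, so a limit is again likely. Compound 4 is expected at 100000 nM, between 50000 nM and 300000 nM.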

Compound 4, half-maximal cytotoxic concentration: > 100000 nM
Compound 4: no number, only a limit; the forecaster's own chance of this, stated with the estimate: 70%; the middle value lies on the limit itself.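

In this assay, fluoro in place of hydrogen on an aromatic carbon also gives a higher number on the core of compound 2, with an at least 8.3-fold higher number from compound 2 to compound 4 (0.92 log units; beyond the scatter). The direction therefore repeats on the two cores shown, but their sizes cannot be compared: the same change on two cores in this assay, an at least 6.6-fold higher number (0.82 log units; beyond the scatter) from compound 1 to compound 3 and an at least 8.3-fold higher number (0.92 log units; beyond the scatter) from compound 2 to compound 4; the limit leaves it open whether they differ. The step from compound 3 to compound 4 cannot be read, so these results do not show what chloro in place of hydrogen does when fluoro is present: the limit of > 100000 nM in this assay, at which 2 of the 4 values shown sit.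

The compounds shown leave open whether an amine or a methoxy group in place of the fluoro would shift the number in this assay. They also leave open whether a longer chain to the ring bearing the two carbonyl groups would do so.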